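The source may hold more compounds than are shown below. What is called first, only, known or untested is meant among the compounds shown, and "the series" means these compounds.

Measured so far:
- compound 1, `COc1cccc(/C=C/C(=O)OC[C@H]2O[C@@H](Oc3ccc(C(C)=O)cc3)[C@H](O)[C@@H](O)[C@@H]2O)c1`: > 1510000 nM
- compound 2, `CC(=O)c1ccc(O[C@@H]2O[C@H](COC(=O)/C=C/c3cccc(F)c3)[C@@H](O)[C@H](O)[C@H]2O)cc1`: 828000 nM
- compound 3, `CC(=O)c1ccc(O[C@@H]2O[C@H](COC(=O)c3ccccc3)[C@@H](O)[C@H](O)[C@H]2O)cc1`: 1050000 nM

In an ADME assay on HepG2 2.2.15 cells (Homo sapiens) for cytotoxicity, read by MTT assay (on this read-out lower numbers stand for higher toxicity in this test and higher numbers for lower toxicity in this test), compound 1 gave only a limit, > 1510000 nM, and not a number. Compound 2 gave 828000 nM and compound 3 gave 1050000 nM; the gap between them, a 1.3-fold higher number from compound 2 to compound 3 (0.10 log units; within the scatter), lies within the scatter, so compound 3 stands level with compound 2 on the two numbers that exist. The step that starts from the limit of compound 1, an at least 1.4-fold lower number from compound 1 to compound 3 (0.15 log units; that floor lies within the scatter), is only a floor.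

Compound 4, `CC(=O)c1ccc(O[C@@H]2O[C@H](CO[C@@H]3OC[C@@H](O)[C@H](O)[C@H]3O)[C@@H](O)[C@H](O)[C@H]2O)cc1`, has not been measured. It differs from compound 3 by 3,4,5-trihydroxyoxan-2-yl in place of benzoyl on an oxygen on a saturated carbon. Among the measured compounds shown here, none of the measured steps covers a change of this kind: an at least 1.8-fold lower number from compound 1 to compound 2 (0.26 log units; that floor lies within the scatter) swaps one small group on an aromatic ring, and an at least 1.4-fold lower number from compound 1 to compound 3 (0.15 log units; that floor lies within the scatter) and a 1.3-fold higher number from compound 2 to compound 3 (0.10 log units; within the scatter) trade one carbonyl substituent for another while keeping an aromatic ring. For the measured compounds named here, with no step of the same kind, and with all three compounds sitting near the top of the tested range, no movement beyond the scatter is expected in this assay, and the estimated step is a 1.3-fold higher number from compound 3 to compound 4 (0.12 log units; within the scatter). Compound 4 is therefore expected to give about 1400000 nM, somewhere between 700000 nM and 3000000 nM, quite possibly reported only as a limit.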

Compound 4, half-maximal cytotoxic concentration: > 2590000 nM
Compound 4 ended at the assay's limit (the forecaster's own chance of this, stated with the estimate: 55%); middle value at least 1.8-fold (0.26 log units) from the limit.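

Among the compounds shown here, at this position, an oxygen on a saturated carbon, the earlier compounds only traded one carbonyl substituent for another, and those steps were either within the scatter or floors within it. For the compounds shown here, replacing benzoyl with 3,4,5-trihydroxyoxan-2-yl removes both the aromatic ring and the carbonyl from this place, and in this assay it gives an at least 2.4-fold higher number from compound 3 to compound 4 (0.39 log units; beyond the scatter), the first step here to clear the scatter, in the direction of lower toxicity in this test. This size is only a floor, since compound 4 gave a limit and not a number: the limit of > 2590000 nM in this assay, at which 1 of the 4 values shown sits.

The compounds shown leave open whether the shift comes from the incoming ring with its hydroxyl groups or simply from the loss of benzoyl. A small acetyl group or a chain ending in a carboxylic acid on this oxygen would help to separate the two.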